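Methoxy replacing hydrogen on a pyrazoloquinoline-type shared core

The compounds below may be only part of what the source reports. "The series", "measured", "known", "first", "only" and "open" are said of these compounds alone.

Measured compounds:
Compound 1 `Cc1ccc(-c2nc3c(c(-c4ccccc4)nn3-c3ccccc3)c(-c3ccc(O)cc3)c2C#N)cc1` gives 8800 nM in a functional assay on K562 cells (Homo sapiens) for antiproliferative activity, read by resazurin assay, with a stated time of 72 h; a lower number here means a stronger inhibitor, a higher number a weaker inhibitor.
Compound 2 `N#Cc1c(-c2ccccc2)nc2c(c(-c3ccccc3)nn2-c2ccccc2)c1-c1ccc(O)cc1` gives 9600 nM in this assay.
Compound 3 `N#Cc1c(-c2cccs2)nc2c(c(-c3ccccc3)nn2-c2ccccc2)c1-c1ccc(O)cc1` gives 11600 nM in this assay.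

Compound 2 has the second highest of the three numbers, and its steps to compound 1 and compound 3 (a 1.1-fold higher number from compound 1 to compound 2 (0.04 log units; within the scatter); a 1.2-fold higher number from compound 2 to compound 3 (0.08 log units; within the scatter)) are both within the scatter. Compound 4 `COc1ccc(-c2nc3c(c(-c4ccccc4)nn3-c3ccccc3)c(-c3ccc(O)cc3)c2C#N)cc1` differs from compound 2 by methoxy in place of hydrogen on an aromatic carbon. The step that bears most directly on this change is the substituent swap at the same place, a 1.1-fold higher number from compound 1 to compound 2 (0.04 log units; within the scatter), which lay within the scatter, as did a 1.3-fold higher number from compound 1 to compound 3 (0.12 log units; within the scatter). No step beyond the scatter is therefore expected in this assay. Compound 4 is estimated at 9000 nM, with a range of 4500 nM to 18000 nM, meaning an expected step of a 1.1-fold lower number from compound 2 to compound 4 (0.03 log units; within the scatter).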

Compound 4, half-maximal inhibitory concentration: 2100 nM
The estimate for compound 4 lay 4.3-fold (0.63 log units) above the measured number, outside the stated range (below it).
By their numbers in this assay, from the lowest: compound 4; then compounds 1, 2 and 3 (each within the scatter of the next).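

In this assay, this position proved responsive to its substituent: phenyl, 4-methylphenyl and thiophen-2-yl had stayed within the scatter of one another, but 4-methoxyphenyl stands apart from all three (a 4.6-fold lower number from compound 2 to compound 4 (0.66 log units; beyond the scatter); a 4.2-fold lower number from compound 1 to compound 4 (0.62 log units; beyond the scatter); a 5.5-fold lower number from compound 3 to compound 4 (0.74 log units; beyond the scatter)). The step from methyl to methoxy shows that a small group on this ring does not by itself bring the change, since methyl had not moved the number beyond the scatter. Nothing available here accounts for the methoxy step. As far as these compounds go, whether ethoxy, hydroxy or a dimethylamino group at the same place would match methoxy remains open. So does whether methoxy would give a similar step elsewhere on the ring.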